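The source may report more compounds than this note shows. Statements on the series, on what has been measured and on what is new or still open speak of the compounds shown alone.

Measured in an ADME assay on MT4 cells (Homo sapiens) for cytotoxicity, read by MTT assay, with a stated time of 5 days; a higher number here means that more compound is tolerated, a lower number that less compound is tolerated:
compound 1, `Cc1cc(/C=C/C#N)cc(C)c1Oc1cc(NCCN(C)C)nc(Nc2ccc(C#N)cc2)n1`: 3040 nM
compound 2, `Cc1cc(/C=C/C#N)cc(C)c1Oc1cc(NCCC#N)nc(Nc2ccc(C#N)cc2)n1`: 1000 nM
compound 3, `Cc1cc(/C=C/C#N)cc(C)c1Oc1cc(NCCN2CCNCC2)nc(Nc2ccc(C#N)cc2)n1`: 3650 nM

Compound 3 has the highest of the three numbers in this assay; its nearest neighbour is compound 1, with a 1.2-fold higher number from compound 1 to compound 3 (0.08 log units; within the scatter), and its furthest is compound 2, with a 3.7-fold higher number from compound 2 to compound 3 (0.56 log units; beyond the scatter). Compound 4, `Cc1cc(/C=C/C#N)cc(C)c1Oc1cc(NCC2CCCO2)nc(Nc2ccc(C#N)cc2)n1`, differs from compound 3 on the chain: oxolan-2-yl in place of (piperazin-1-yl)methyl on a saturated chain carbon bound to a nitrogen on an aromatic ring. The two steps beyond the scatter both concern that chain end, a drop in a 3.0-fold lower number from compound 1 to compound 2 (0.48 log units; beyond the scatter) and the reverse rise in a 3.7-fold higher number from compound 2 to compound 3 (0.56 log units; beyond the scatter), while a 1.2-fold higher number from compound 1 to compound 3 (0.08 log units; within the scatter) changed little. Among the measured compounds shown here, no measured step covers an oxolan-2-yl group, so the expectation rests on the chain end mattering modestly. Compound 4 is therefore expected at 1600 nM (range 600 nM to 4200 nM), a step of a 2.3-fold lower number from compound 3 to compound 4 (0.36 log units; beyond the scatter).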

Compound 4, half-maximal cytotoxic concentration: > 268000 nM
Compound 4 gave a limit, no number; the forecaster's own chance of this, stated with the estimate: 10%; middle value at least 160-fold (2.22 log units) from the limit.
By their numbers in this assay, from the lowest: compound 2; then compounds 1 and 3 (each within the scatter of the next). At a limit, above all of these: compound 4.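

In this assay compound 4 gives a limit, not a number: the limit of > 268000 nM in this assay, at which 1 of the 4 values shown sits. On a saturated chain carbon bound to a nitrogen on an aromatic ring, oxolan-2-yl sets itself far apart from the three earlier chain ends, with an at least 73-fold higher number from compound 3 to compound 4 (1.86 log units; beyond the scatter), an at least 260-fold higher number from compound 2 to compound 4 (2.42 log units; beyond the scatter) and an at least 88-fold higher number from compound 1 to compound 4 (1.94 log units; beyond the scatter). Among the compounds shown here, this chain end can therefore shift the tolerated concentration far more than the earlier steps showed. From the compounds shown here alone, whether the ring or its oxygen carries this stays open: a cyclopentyl ring, an open methoxyethyl chain or an oxan-2-yl ring could separate the two.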